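This account rests on a few compounds, and the source may have more. Where it says the series, first, only, none or still open, it means among the compounds named here.

Measured so far:
compound 1, `Cc1nsc2[nH]cnc12`, gives 17000 nM in a functional assay on L1210 cells (Mus musculus) for antiproliferative activity; on this read-out higher numbers stand for weaker inhibition and lower numbers for stronger inhibition
compound 2, `CSc1nc2c(C)nsc2[nH]1`, gives 13000 nM in this assay
compound 3, `Cc1nsc2c1ncn2[C@@H]1O[C@H](CO)[C@@H](O)[C@H]1O`, gives 10000 nM in this assay

Compound 4, `CSc1nc2c(C)nsc2n1[C@@H]1O[C@H](CO)[C@@H](O)[C@H]1O`, is not yet measured. It arises from compound 3 by the change (methylsulfanyl in place of hydrogen on an aromatic carbon). The same kind of change occurs once among the measured compounds: compound 2 arises from compound 1 by methylsulfanyl in place of hydrogen on an aromatic carbon, and that step gave a 1.3-fold lower number from compound 1 to compound 2 (0.12 log units; within the scatter). The two places are not identical in their description: in compound 3 the carbon that takes the methylsulfanyl is next to the ring atom that bears a group of 9 heavy atoms, a neighbour that is not noted for compound 1, so the change is the same kind of change, not the same. How the core of compound 3 differs from the core of compound 1 is not broken down here; the values of compound 1 and compound 3 in this assay lie within the usual scatter of each other.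

Going by the values given here, on the single earlier step of a 1.3-fold lower number from compound 1 to compound 2 (0.12 log units; within the scatter), the expected step is a 1.3-fold lower number from compound 3 to compound 4 (0.10 log units; within the scatter). Compound 4 is therefore estimated at 8000 nM, between 3000 nM and 20000 nM.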

Compound 4, half-maximal inhibitory concentration: > 100000 nM
Compound 4: a limit, no number; the forecaster's own chance of this, stated with the estimate: 5%; middle value at least 12-fold (1.09 log units) away from the limit.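

In this assay, methylsulfanyl in place of hydrogen on an aromatic carbon gave an at least 10-fold higher number from compound 3 to compound 4 (1.00 log units; beyond the scatter), so the change did not carry over unaltered from one core to the other: the same change on two cores in this assay, a 1.3-fold lower number (0.12 log units; within the scatter) from compound 1 to compound 2 and an at least 10-fold higher number (1.00 log units; beyond the scatter) from compound 3 to compound 4, at least 13-fold (1.11 log units) apart, beyond the scatter of two such steps

Compound 4 gives > 100000 nM, which is a limit of the assay and not a number.

Going by these compounds alone, with only two steps, the comparison shows that the outcome of this change depends on the compound that receives it, but not what sets the two steps apart or how large the second one really is; in compound 4 the methylsulfanyl sits next to the ring atom that bears a group of 9 heavy atoms, a neighbour not noted for compound 1, but these compounds cannot single that out as the reason.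

The compounds shown leave open whether an amine or a longer sulfur-linked chain in place of the methylsulfanyl would follow the step on the core of compound 1 or the one on the core of compound 3. They also leave open whether the same holds for other groups on the ring nitrogen, such as a plain methyl.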